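Ester alkyl variation and microsomal stability in the series

This account rests on a few compounds, and the source may have more. Where it says the series, first, only, none or still open, it means among the compounds named here.

Measured so far in an ADME assay on microsomes from liver (Mus musculus) for metabolic stability, with a stated time of 30 min; on this read-out lower numbers stand for a less stable compound and higher numbers for a more stable compound:
compound 1 `CCCCc1nc(C(C)C)c(CC(=O)OCCC)c(=O)n1Cc1ccc(-c2ccccc2-c2noc(=O)[nH]2)cc1` gives 12.6%
compound 2 `CCCCOC(=O)Cc1c(C(C)C)nc(CCCC)n(Cc2ccc(-c3ccccc3-c3noc(=O)[nH]3)cc2)c1=O` gives 21.6%
compound 3 `CCCCc1nc(C(C)C)c(CC(=O)OC2CC2)c(=O)n1Cc1ccc(-c2ccccc2-c2noc(=O)[nH]2)cc1` gives 11.4%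

Compound 3 stands at the low end of these three: its difference from compound 1 is within the scatter a number 1.2 percentage points lower from compound 1 to compound 3 (within the scatter), and it lies beyond the scatter below compound 2 a number 10.2 percentage points lower from compound 2 to compound 3 (beyond the scatter). Compound 4 `CCCCc1nc(C(C)C)c(CC(=O)OC(CC)CC)c(=O)n1Cc1ccc(-c2ccccc2-c2noc(=O)[nH]2)cc1` carries pentan-3-yl in place of cyclopropyl on an oxygen next to a carbonyl group. The two steps that bear on this both replace cyclopropyl on the ester oxygen with a straight chain: a number 1.2 percentage points lower from compound 1 to compound 3 (within the scatter) and a number 10.2 percentage points lower from compound 2 to compound 3 (beyond the scatter), the longer chain giving the modest gain. A five-carbon branched chain is expected to move this assay in the same direction, by a number 8.6 percentage points higher from compound 3 to compound 4 (within the scatter), so compound 4 is estimated at 20% with a range of 9% to 34%.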

Compound 4, percent of the compound remaining: 14.6%
Compound 4: the middle estimate sits 5.4 percentage points above what was measured; the range from low to high includes it.
By their numbers in this assay, from the lowest: compounds 3, 1, 4 and 2 (each within the scatter of the next, the first and the last beyond it).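

In this assay pentan-3-yl on an oxygen next to a carbonyl group stays within the scatter of cyclopropyl (a number 3.2 percentage points higher from compound 3 to compound 4 (within the scatter)), propyl (a number 2 percentage points higher from compound 1 to compound 4 (within the scatter)) and butyl (a number 7 percentage points lower from compound 2 to compound 4 (within the scatter)). Branching with five carbons therefore gives no step beyond the scatter here, and butyl against cyclopropyl remains the only such pair at this position. No measured evidence bears on this result.

On these data alone, whether a longer chain such as octyl or a tert-butyl group on this oxygen would leave the scatter remains open.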